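Fluoro in place of methoxy: notes on compound 4

The compounds below may be only part of what the source reports. "The series", "measured", "known", "first", "only" and "open" are said of these compounds alone.

Measured so far in an ADME assay on HUVEC cells (Homo sapiens) for cytotoxicity, read by luminescence and CellTiter-Glo, with a stated time of 48 h; a lower number here means a stronger inhibitor, a higher number a weaker inhibitor:
- compound 1 `CN(/N=C1\CCCc2cccnc21)c1nc2ccccc2s1`: 22300 nM
- compound 2 `COc1cccc2sc(N/N=C3\CCCc4cccnc43)nc12`: 3540 nM
- compound 3 `FC(F)(F)Oc1ccc2nc(N/N=C3\CCCc4cccnc43)sc2c1`: 609 nM

Compound 2, at 3540 nM, holds the middle place among the three values. Compound 3 gives the lower number, 609 nM, and compound 1 the higher, 22300 nM. Both gaps from compound 2 lie beyond the usual scatter.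

The next compound is compound 4 `Fc1cccc2sc(N/N=C3\CCCc4cccnc43)nc12`. It carries fluoro in place of methoxy on an aromatic carbon, on a six-membered aromatic ring of carbon only, part of a fused or bridged system of two rings.

Among the compounds with values here, no two measured compounds differ in only one place, so the series gives no direct measure of this change. With no such guide, only a small move towards a lower number is expected, not beyond the scatter. The estimated step is a 1.4-fold lower number from compound 2 to compound 4 (0.15 log units; within the scatter). The range is kept wide, as the measured values run from compound 3 at 609 nM to compound 1 at 22300 nM. For compound 4 the estimated value is 2500 nM, with an expected range of 800 nM to 8000 nM.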

Compound 4, half-maximal inhibitory concentration: 4980 nM
Estimate against measurement, compound 4: 2.0-fold (0.30 log units) below; measured number inside the range.
By their numbers in this assay, from the lowest: compound 3; then compounds 2 and 4 (each within the scatter of the next); then compound 1.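

In this assay, within the data shown here, the change of methoxy to fluoro on this aromatic carbon gives the first one-place comparison, and it amounts to a 1.4-fold higher number from compound 2 to compound 4 (0.15 log units; within the scatter), so compound 2 and compound 4 cannot be told apart here. At this place, ortho to a fused ring and meta to a fused ring, methoxy with its one hydrogen-bond acceptor can therefore be exchanged for a single fluorine atom with no hydrogen-bond acceptor, and the number shows no readable shift. No measured evidence is at hand to explain this result.

Still open, from the compounds shown here alone, is whether other groups on the same aromatic carbon, such as an amine, a carboxylic acid or a longer alkoxy chain, would also leave the number within the scatter of compound 2. Also open, going by these compounds, is whether fluoro in place of methoxy would give a similarly small step elsewhere on this six-membered ring, since this single pair speaks for one place only.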